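The compounds below may be only part of what the source reports. "The series", "measured", "known", "first", "only" and "open" are said of these compounds alone.

Compound 1, `Cc1nn(C)c2c1C(c1ccc(C(F)(F)F)cc1)C(C#N)=C(N)O2`, serves as the starting point of this small set. In a functional assay on NCI-H2122 cells (Homo sapiens) for inhibition, read by microscopy, with a stated time of 10 days (on this read-out higher numbers stand for weaker inhibition and lower numbers for stronger inhibition), compound 1 gives 2200 nM. Compound 2, `Cn1nc(-c2ccccc2)c2c1OC(N)=C(C#N)C2c1ccc(C(F)(F)F)cc1`, differs from compound 1 by phenyl in place of methyl on an aromatic carbon. In this assay compound 2 gives 4100 nM, and the step is a 1.9-fold higher number from compound 1 to compound 2 (0.27 log units; within the scatter). Compound 3, `Cc1nn(C)c2c1C(c1ccc(C(C)C)cc1)C(C#N)=C(N)O2`, keeps the methyl group of compound 1 on the fused core but carries a different group on the phenyl ring; the difference between the two cores is isopropyl in place of trifluoromethyl on an aromatic carbon. In this assay compound 3 gives 4000 nM, a step of a 1.8-fold higher number from compound 1 to compound 3 (0.26 log units; within the scatter). The values of compound 2 and compound 3 lie within the scatter of each other, so nothing separates them.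

Compound 4, `CC(C)c1ccc(C2C(C#N)=C(N)Oc3c2c(-c2ccccc2)nn3C)cc1`, has not yet been measured in this assay. It differs from compound 3 by phenyl in place of methyl on an aromatic carbon. This is the same change that turns compound 1 into compound 2, and the place in which it is made is described in the same words for both pairs; the two changes therefore count as the same change, made once on each of the two cores. Because the step of a 1.9-fold higher number from compound 1 to compound 2 (0.27 log units; within the scatter) stayed within the scatter, the step from compound 3 to compound 4 is expected to be of similar size, estimated as a 1.9-fold higher number from compound 3 to compound 4 (0.27 log units; within the scatter). On that basis compound 4 is expected to give about 7500 nM in this assay, with the estimate spanning 3500 nM to 16000 nM.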

Compound 4, half-maximal inhibitory concentration: 5400 nM
Beside the measured number, compound 4's estimate is 1.4-fold (0.14 log units) above it; low and high end bracket the measured number.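

On the core of compound 3, phenyl in place of methyl on an aromatic carbon gives a 1.4-fold higher number from compound 3 to compound 4 (0.13 log units; within the scatter) in this assay, and the step matches the one seen for this change on the core of compound 1: the same change on two cores in this assay, a 1.9-fold higher number (0.27 log units; within the scatter) from compound 1 to compound 2 and a 1.4-fold higher number (0.13 log units; within the scatter) from compound 3 to compound 4, 1.4-fold (0.14 log units) apart, within the scatter of two such steps

The second change reads the same way, with isopropyl in place of trifluoromethyl on an aromatic carbon giving a 1.3-fold higher number from compound 2 to compound 4 (0.12 log units; within the scatter), which matches its earlier step on the other core: the same change on two cores in this assay, a 1.8-fold higher number (0.26 log units; within the scatter) from compound 1 to compound 3 and a 1.3-fold higher number (0.12 log units; within the scatter) from compound 2 to compound 4, 1.4-fold (0.14 log units) apart, within the scatter of two such steps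

This shows that, across these four compounds, each change has a step of similar size on both cores, but all four steps lie within the scatter, so the agreement is one between small steps and does not show that a step beyond the scatter would carry over in the same way, nor that the two changes act independently of each other in the series at large.

The compounds shown leave open whether this agreement would hold with an amine or a longer chain on the aromatic carbon that bears methyl or phenyl, or with a carboxylic acid on the phenyl ring that bears trifluoromethyl or isopropyl. From the compounds shown here alone, they also cover a single cell line and read-out, so it remains open whether the same agreement would appear on any other cell line.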